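Trimming a ring down to a hydroxymethyl ethyl side chain

The source may report more compounds than this note shows. Statements on the series, on what has been measured and on what is new or still open speak of the compounds shown alone.

For the measured compounds named here, in an assay for inhibition of histone-lysine N-methyltransferase EZH2 variant Y641N (Homo sapiens), read by scintillation counting, with a stated time of 60 min, in the presence of a further agent that is not named here (on this read-out lower numbers stand for stronger inhibition and higher numbers for weaker inhibition), compound 1 `Cc1cc(C)c(CN2CCc3c(Cl)cc([C@@H](CO)[C@@H]4CCOC4)c(Cl)c3C2=O)c(=O)[nH]1` gives 1260 nM, the only number recorded for it, with one further entry that carries no single value. Compound 2 `COC(c1cc(Cl)c2c(c1Cl)C(=O)N(Cc1c(C)cc(C)[nH]c1=O)CC2)C1CCN(C(C)=O)CC1` gives 157 nM; 0.15 nM (2 entries) in this assay, a spread noted in the several entries of compound 2 in this assay, 157 nM; 0.15 nM (2 entries). Compound 3 `Cc1cc(C)c(CN2CCc3c(Cl)cc([C@@H](C)CO)c(Cl)c3C2=O)c(=O)[nH]1` differs from compound 1 by a group of 4 heavy atoms (3 carbon, 1 oxygen; no ring) in place of a group of 8 heavy atoms (6 carbon, 2 oxygen; one five-membered non-aromatic ring with 1 hetero atom), on an aromatic carbon. Going by the values given here, no step between measured compounds is available, so the size of this step rests on the change alone; the account expects a modest weakening in this assay, a 2.0-fold higher number from compound 1 to compound 3 (0.30 log units; within the scatter). Compound 3 is therefore estimated at 2500 nM, within 600 nM to 10000 nM.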

Compound 3, inhibition constant: 260 nM
Beside the measured number, compound 3's estimate is 9.6-fold (0.98 log units) above it, and the stated range ends above it.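

In this assay, the 1-(hydroxymethyl)ethyl group at this aromatic carbon, in place of the larger group with its five-membered ring, brings a 4.8-fold lower number from compound 1 to compound 3 (0.69 log units; beyond the scatter) and so runs opposite to a loss of strength on trimming. The five-membered ring is therefore not required at this position for a number of this order. Single numbers in this assay still call for care, as one compound shows: the several entries of compound 2 in this assay, 157 nM; 0.15 nM (2 entries).

On these data alone, whether an amine in place of the hydroxyl, or a longer chain, would hold this gain remains open. So does the role of the one defined stereocentre in the new group.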